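The source may hold more compounds than are shown below. What is called first, only, known or untested is meant among the compounds shown, and "the series" means these compounds.

Of the compounds shown here, three sharing one core have been measured in an assay on isolated protein (Mus musculus) for inhibition of IL15-IL15 receptor (Homo sapiens), read by resazurin assay, with stated times of 30 min and 2.5 days; a lower number here means a stronger inhibitor, a higher number a weaker inhibitor. Compound 1 `CC(C)COc1ccc(NC(=O)CCCCCCCSc2nnc(Cc3nn(C)c(=O)c4ccccc34)n2C)cc1` gives 4800 nM. Compound 2 `Cn1c(Cc2nn(C)c(=O)c3ccccc23)nnc1SCCCCCCCC(=O)Nc1ccc(O)cc1O` gives 17000 nM. Compound 3 `Cn1c(Cc2nn(C)c(=O)c3ccccc23)nnc1SCCCCCCCC(=O)Nc1ccc(I)cc1` gives 1300 nM, the lowest of the three numbers; the steps of a 3.7-fold lower number from compound 1 to compound 3 (0.57 log units; beyond the scatter) and a 13-fold lower number from compound 2 to compound 3 (1.12 log units; beyond the scatter) are both beyond the scatter.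

Compound 4 `Cn1c(Cc2nn(C)c(=O)c3ccccc23)nnc1SCCCCCCCC(=O)Nc1ccc(O)cc1` is not yet measured. It differs from compound 3 in one place: hydroxy in place of iodo on an aromatic carbon. For the measured compounds named here, two measured steps bear on this change, since both replace an oxygen-bearing substituent on the phenyl ring with iodo and both lower the number: the step of a 3.7-fold lower number from compound 1 to compound 3 (0.57 log units; beyond the scatter) is modest, while the step of a 13-fold lower number from compound 2 to compound 3 (1.12 log units; beyond the scatter) is large, with compound 2 carrying a hydroxy in the same position as the new group of compound 4 together with a second one. Going the other way, from iodo back to hydroxy, the number is therefore expected to rise in this assay, most likely by an amount between those two steps.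

Compound 4 is accordingly expected to give 8000 nM in this assay, within a range of 3000 nM to 25000 nM, which means an expected step of a 6.2-fold higher number from compound 3 to compound 4 (0.79 log units; beyond the scatter).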

Compound 4, half-maximal inhibitory concentration: > 30000 nM
Compound 4: a limit, no number (the forecaster's own chance of this, stated with the estimate: 10%); middle value at least 3.7-fold (0.57 log units) from the limit.
By their numbers in this assay, from the lowest: compound 3; then compound 1; then compound 2. At a limit, above all of these: compound 4.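

In this assay compound 4 can be read only as a limit, not as a number: the limit of > 30000 nM in this assay, at which 1 of the 4 values shown sits. For the compounds shown here, earlier comparisons changed the ring in more than one way or kept a substituted oxygen, whereas here a single hydroxy para to a large group replaces iodo, giving an at least 23-fold higher number from compound 3 to compound 4 (1.36 log units; beyond the scatter) and, when hydrogen replaces the isobutyl on that oxygen, an at least 6.2-fold higher number from compound 1 to compound 4 (0.79 log units; beyond the scatter). The second hydroxy of the earlier dihydroxy compound is not shown to matter, since the step of an at least 1.7-fold higher number from compound 2 to compound 4 (0.24 log units; that floor lies within the scatter) has a floor that cannot separate the two compounds, so the loss seen with hydroxy does not depend on that extra group.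

On these data alone, whether a chloro, a bromo or a methoxy at this place would stay close to compound 3 or fall toward compound 4 remains open, as does the behaviour of an amine or a carboxylic acid there. As far as these compounds go, the true size of the loss also remains open, and so does whether a longer chain in the linker would change how much this position matters.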